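From 4-methoxyphenyl to 2-bromophenyl on a shared core

The source may hold more compounds than are shown below. What is called first, only, known or untested is meant among the compounds shown, and "the series" means these compounds.

- Compound 1 `COc1ccccc1C(=O)n1c(-c2cn(C)c3ccccc23)nc2ccccc21`: 31800 nM
- Compound 2 `COc1cccc(C(=O)n2c(-c3cn(C)c4ccccc34)nc3ccccc32)c1`: 13600 nM
- Compound 3 `COc1ccc(C(=O)n2c(-c3cn(C)c4ccccc34)nc3ccccc32)cc1`: 15200 nM
- Compound 4 `Cn1cc(-c2nc3ccccc3n2C(=O)c2ccccc2Br)c2ccccc21`: not yet measured

In a functional assay on HepG2 cells (Homo sapiens) for inhibition, read by MTT assay, with a stated time of 24 h (on this read-out lower numbers stand for stronger inhibition of growth and higher numbers for weaker inhibition of growth), compound 3 sits level with compound 2, showing a 1.1-fold higher number from compound 2 to compound 3 (0.05 log units; within the scatter). Compound 1 lies apart from it, with a 2.1-fold lower number from compound 1 to compound 3 (0.32 log units; beyond the scatter). Compound 4 has 2-bromophenyl in place of 4-methoxyphenyl on a carbonyl carbon. Among the compounds with values here, no measured compound carries 2-bromophenyl, so the evidence is indirect. Within the data shown here, the closest guide is compound 1, the only one with a group named at position 2, and its steps were modest, including a 2.3-fold lower number from compound 1 to compound 2 (0.37 log units; beyond the scatter). The expected change is therefore small and toward a higher number, an estimated 1.8-fold higher number from compound 3 to compound 4 (0.25 log units; within the scatter). Compound 4 is expected at 27000 nM, within an estimated range of 11000 nM to 60000 nM.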

Compound 4, concentration for 50% growth inhibition: 68200 nM
Estimate against measurement, compound 4: 2.5-fold (0.40 log units) below, and the stated range ends below it.
By their numbers in this assay, from the lowest: compounds 2 and 3 (each within the scatter of the next); then compound 1; then compound 4.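

Read in this assay the change to 2-bromophenyl on the carbonyl carbon gives a 4.5-fold higher number from compound 3 to compound 4 (0.65 log units; beyond the scatter) and a 5.0-fold higher number from compound 2 to compound 4 (0.70 log units; beyond the scatter), both larger steps than any among the methoxy compounds. Bromo in place of methoxy on an aromatic carbon gives a 2.1-fold higher number from compound 1 to compound 4 (0.33 log units; beyond the scatter) so the group itself changes the number, and not only where it stands on the phenyl ring. Nothing measured here explains why these steps go this way. From the compounds shown here alone, whether an amine or a carboxylic acid in place of bromo would give a lower or a higher number stays open.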